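This account rests on a few compounds, and the source may have more. Where it says the series, first, only, none or still open, it means among the compounds named here.

Measured compounds:
- compound 1, `COc1cc(C)cc(-c2c(-c3ccnc(-c4ccc(C(C)=O)cc4)c3)cnn2CC#N)c1`: 3420 nM
- compound 2, `COc1cc(C)cc(-c2nn(CC#N)cc2-c2ccnc(-c3ccc(N(C)C)cc3)c2)c1`: 319 nM

In a functional assay on DU-145 cells (Homo sapiens) for inhibition, read by sulforhodamine B assay, with a stated time of 48 h (a lower number here means a stronger inhibitor of growth, a higher number a weaker inhibitor of growth), compound 1 gives 3420 nM, the highest of the two numbers shown, while compound 2 gives 319 nM, a markedly lower number that lies beyond the scatter. Compound 3, `COc1cc(C)cc(-c2c(-c3ccnc(-c4ccc(N(C)C)cc4)c3)cnn2CC#N)c1`, has not been measured. It differs from compound 1 by dimethylamino in place of acetyl on an aromatic carbon. Among the measured compounds shown here, no measured pair shows this change alone, but compound 2, which carries the same dimethylamino group on a differently arranged shared core, reached 319 nM. A move toward lower numbers is therefore expected, estimated as a 6.8-fold lower number from compound 1 to compound 3 (0.84 log units; beyond the scatter). Compound 3 is expected to give 500 nM, within a range from 150 nM to 1700 nM.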

Compound 3, concentration for 50% growth inhibition: 113 nM
Beside the measured number, compound 3's estimate is 4.4-fold (0.65 log units) above it; measured number below the stated range.
By their numbers in this assay, from the lowest: compound 3; then compound 2; then compound 1.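

In this assay this change can now be read directly on the shared core, as a 30-fold lower number from compound 1 to compound 3 (1.48 log units; beyond the scatter). At this aromatic carbon, para to a large group, the result therefore separates 4-(dimethylamino)phenyl from 4-acetylphenyl, though the two groups have the same count of heavy atoms and of hydrogen-bond acceptors. No available evidence accounts for the size of this step.

As far as these compounds go, whether a primary amine, a methoxy group or a carboxylic acid at this place would give a number closer to that of compound 3 or compound 1 remains open. So does whether acetyl would give a similar step on the differently arranged core of compound 2.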